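The source may hold more compounds than are shown below. What is called first, only, known or untested is meant among the compounds shown, and "the series" means these compounds.

Among the compounds with values here, compound 1 `O/N=C(/Nc1ccccc1)c1ccc2occc2c1` is the only member of the set with a full number in an assay on tissue (HeLa cells) for inhibition of Indoleamine 2,3-dioxygenase 1 (Homo sapiens), read by spectrophotometry; on this read-out higher numbers stand for weaker inhibition and lower numbers for stronger inhibition: compound 1 gives 19000 nM. Compound 2 `O/N=C(/Nc1cccc(Cc2ccccc2)c1)c1ccc2occc2c1` carries a benzyl on an aromatic carbon of the shared core. In this assay compound 2 reaches only > 30000 nM, which is a limit of the method and not a number. Within the data shown here, the step of an at least 1.5-fold higher number from compound 1 to compound 2 (0.19 log units; that floor lies within the scatter) therefore has a floor that lies within the scatter, and the set holds no other measured step. Compound 3 `O/N=C(/NCc1ccco1)c1ccc2occc2c1` differs from compound 1 in a different place: (furan-2-yl)methyl in place of phenyl on an amine nitrogen. Among the measured compounds shown here, no measured step touches that nitrogen, so the benzyl step offers only a loose guide, and no change beyond the scatter is expected in this assay. Compound 3 is accordingly estimated at about 20000 nM, within a range from 6000 nM to 60000 nM. The step of a 1.1-fold higher number from compound 1 to compound 3 (0.02 log units; within the scatter) is thus expected to be essentially flat.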

Compound 3, half-maximal inhibitory concentration: > 30000 nM
Compound 3 ended at the assay's limit (the forecaster's own chance of this, stated with the estimate: 30%); middle value at least 1.5-fold (0.17 log units) from the limit.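

The amine nitrogen now has a measured step of its own: in this assay, (furan-2-yl)methyl in place of phenyl gives an at least 1.5-fold higher number from compound 1 to compound 3 (0.19 log units; that floor lies within the scatter). Compound 3 gives > 30000 nM, which is a limit of the assay and not a number. This change at the nitrogen therefore yields no full number, and its true size cannot be read, since only a floor is available: the limit of > 30000 nM in this assay, at which 2 of the 3 values shown sit.

The compounds shown leave open whether any group on this nitrogen gives a full number in this assay that can be set against compound 1. A benzyl or a pyridin-2-ylmethyl there would separate the added carbon link from the change of ring, and a plain methyl or a longer chain would show what happens with no ring at all.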